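This account rests on a few compounds, and the source may have more. Where it says the series, first, only, none or still open, it means among the compounds named here.

Measured in an ADME assay on HEK293 cells (Homo sapiens) for cytotoxicity, with a stated time of 72 h; on this read-out higher numbers stand for an effect only at larger amounts of compound and lower numbers for an effect already at smaller amounts:

Compound 1 `C=C[C@@](C)(/C=C/c1ccc(Nc2ccc(F)cc2)cc1)CCC=C(C)C`: > 36600 nM, a limit.
Compound 2 `C=C[C@@](C)(/C=C/c1ccc(Nc2ccc(F)c(F)c2)cc1)CCC=C(C)C`: > 36600 nM, a limit.
Compound 3 `C=C[C@@](C)(/C=C/c1ccc(-c2ccc(Cl)c(Cl)c2)cc1)CCC=C(C)C`: > 36600 nM, a limit.

Compound 3 has no number in this assay, and its entry of > 36600 nM is only a limit. It shares this position with the other two compounds, as the limit of > 36600 nM in this assay, at which 3 of the 3 values shown sit, shows.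

Compound 4 `C=C[C@@](C)(/C=C/c1ccc(-c2cccc(Br)c2)cc1)CCC=C(C)C` has not yet been measured. The change is 3-bromophenyl in place of 3,4-dichlorophenyl on an aromatic carbon, para to a large group.

The measured changes closest to this one are a step that the two limits leave unreadable from compound 1 to compound 3 and a step that the two limits leave unreadable from compound 2 to compound 3, and the fluoro change gives a step that the two limits leave unreadable from compound 1 to compound 2. None of these supplies a size or a direction. The expectation therefore rests on the limit of > 36600 nM in this assay, at which 3 of the 3 values shown sit, alone, and no step beyond the scatter is expected in this assay, in either direction. The estimated change is a number no higher from compound 3 to compound 4 (the limit leaves the size open). For compound 4 the expected value is 36600 nM, within an estimated range of 18000 nM to 50000 nM.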

Compound 4, half-maximal effective concentration: > 36600 nM
Compound 4 gave a limit, no number; the forecaster's own chance of this, stated with the estimate: 85%; the middle value sits exactly at the limit.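

In this assay, among the compounds shown here, compound 4 gives > 36600 nM, a limit and not a number, so no step from compound 1, compound 2 or compound 3 to compound 4 can be read. The compounds shown leave open whether any of these group changes alters the read-out at all: the limit of > 36600 nM in this assay, at which 4 of the 4 values shown sit.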